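The source may hold more compounds than are shown below. What is called first, only, known or untested is meant among the compounds shown, and "the series" means these compounds.

Measured compounds:
- Compound 1, `COc1ccc(/C=C/C(=O)c2c(OC)cc(O)c(CC=C(C)C)c2O)cc1OC`, gives 15700 nM.
- Compound 2, `COc1cc(OC)c(OC)cc1/C=C/C(=O)c1c(OC)cc(O)c(CC=C(C)C)c1O`, gives 14400 nM.
- Compound 3, `COc1cc(O)cc(O)c1C(=O)/C=C/c1ccc(O)cc1`, gives only a limit, > 50000 nM.

All three were tested in a functional assay on A549 cells (Homo sapiens) for inhibition, read by MTT assay, with a stated time of 72 h (on this read-out higher numbers stand for weaker inhibition and lower numbers for stronger inhibition), so a smaller number means the cells were held back at a lower concentration. Among the compounds with values here, compound 1 and compound 2 share one core, and the single change between them is methoxy in place of hydrogen on an aromatic carbon. This change gave a 1.1-fold lower number from compound 1 to compound 2 (0.04 log units; within the scatter), so the two numbers cannot be told apart.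

Compound 3 sits on a different core, and the difference between the two cores is not broken down here. For compound 3 the value is a limit of the assay rather than a number, as the line the limit of > 50000 nM in this assay, at which 1 of the 3 values shown sits, shows.

Compound 4, `COc1cc(/C=C/C(=O)c2c(O)cc(O)cc2OC)ccc1O`, has not yet been measured. It arises from compound 3 by methoxy in place of hydrogen on an aromatic carbon. Within the data shown here, this is the same kind of change as the one from compound 1 to compound 2, but not the same: in the first case the entering methoxy sat ortho to a large group, meta to a methoxy group and para to a methoxy group, whereas here it sits ortho to a hydroxy group and meta to a large group.

For compound 4 the expected step is a step that the limit leaves unreadable from compound 3 to compound 4, resting on the step of a 1.1-fold lower number from compound 1 to compound 2 (0.04 log units; within the scatter), which stayed within the scatter. Since compound 3 gave only a limit, compound 4 is expected to land near that limit too, with an estimated value of 60000 nM, likely between 25000 nM and 150000 nM.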

Compound 4, half-maximal inhibitory concentration: > 50000 nM
Compound 4 gave a limit, no number; the forecaster's own chance of this, stated with the estimate: 70%; the middle value is on the limit's open side.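

In this assay compound 4 gives > 50000 nM, which is a limit and not a number. Compound 3 also gave only a limit, so no step from compound 3 to compound 4 can be read: the limit of > 50000 nM in this assay, at which 2 of the 4 values shown sit.

The compounds shown leave open whether methoxy in place of hydrogen on an aromatic carbon changes inhibition on this core, and how far apart compound 3 and compound 4 truly lie.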